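Shared-core series: nitroso to chloro at the pyridine-type ring

The source may report more compounds than this note shows. Statements on the series, on what has been measured and on what is new or still open speak of the compounds shown alone.

Compound 3 `CCCN(CCC)c1cc(C)nc2c(-c3ncc(N=O)cc3C)c(C)nn12` gives 100 nM in an assay on isolated protein for binding affinity to corticotropin-releasing factor receptor 1 (Homo sapiens) (a higher number here means a weaker inhibitor, a lower number a stronger inhibitor), the highest of the three numbers; compound 1 `CCCN(CCC)c1cc(C)nc2c(-c3ncc(N)cc3C)c(C)nn12` sits nearest with 85 nM (a 1.2-fold higher number from compound 1 to compound 3 (0.07 log units; within the scatter)), and compound 2 `CCCN(CCC)c1cc(C)nc2c(-c3ncc(N(CC)CC)cc3C)c(C)nn12` is furthest with 13 nM (a 7.7-fold higher number from compound 2 to compound 3 (0.89 log units; beyond the scatter)). The step to compound 4 `CCCN(CCC)c1cc(C)nc2c(-c3ncc(Cl)cc3C)c(C)nn12` puts (one chlorine atom in place of a group of 2 heavy atoms (1 nitrogen, 1 oxygen; no ring), on an aromatic carbon). For the measured compounds named here, no measured step involves chloro. The changes known at this position are a 6.5-fold lower number from compound 1 to compound 2 (0.82 log units; beyond the scatter) and a 1.2-fold higher number from compound 1 to compound 3 (0.07 log units; within the scatter): amino and nitroso lie within the scatter of each other, and only diethylamino moves the number. The step to compound 4 is therefore expected to stay within the scatter: a 1.5-fold lower number from compound 3 to compound 4 (0.19 log units; within the scatter). Compound 4 is estimated at 65 nM, with a range from 20 nM to 200 nM.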

Compound 4, inhibition constant: 6.7 nM
Estimate against measurement, compound 4: 9.7-fold (0.99 log units) above; measured number below the stated range.
By their numbers in this assay, from the lowest: compounds 4 and 2 (each within the scatter of the next); then compounds 1 and 3 (each within the scatter of the next).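

In this assay, for the compounds shown here, chloro breaks clear of the two groups that lay within the scatter of each other (a 15-fold lower number from compound 3 to compound 4 (1.17 log units; beyond the scatter)) and (a 13-fold lower number from compound 1 to compound 4 (1.10 log units; beyond the scatter)), so diethylamino is no longer the only group at this position that moves the number. Chloro and diethylamino, a single chlorine atom and a much larger group, stay within the scatter of each other (a 1.9-fold lower number from compound 2 to compound 4 (0.29 log units; within the scatter)). Nothing measured here explains this difference between the groups. As far as these compounds go, whether fluoro, bromo or methyl at this position would fall with chloro and diethylamino, or with amino and nitroso, remains open.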